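Cyano to fluorophenyl swap in a prenylated stilbene phenol series

The compounds below may be only part of what the source reports. "The series", "measured", "known", "first", "only" and "open" are said of these compounds alone.

Measured so far:
compound 1 `C=C[C@@](C)(/C=C/c1ccc(O)cc1)CCC=O`: in a functional assay on HepG2 cells (Homo sapiens) for cytotoxicity, with a stated time of 72 h (a lower number here means that less compound is needed, a higher number that more compound is needed for the effect), compound 1 gives > 52000 nM
compound 2 `C=C[C@@](C)(/C=C/c1ccc(O)c(/C=C/C#N)c1)CCC=C(C)C`: in this assay compound 2 gives > 52000 nM

The value of compound 1 is a limit of the assay, not a number. The value of compound 2 is likewise a limit. For the measured compounds named here, compound 2 therefore stands at the limit of > 52000 nM in this assay, at which 2 of the 2 values shown sit, with no measured step to any other compound.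

Compound 3 `C=C[C@@](C)(/C=C/c1ccc(O)c(/C=C/c2ccc(F)cc2)c1)CCC=C(C)C` is not yet measured. It differs from compound 2 in one place: 4-fluorophenyl in place of cyano on a double-bonded chain carbon bound to a double-bonded chain carbon. Cut one bond further out, this reads 2-cyanoethenyl to 2-(4-fluorophenyl)ethenyl.

With both shown values at the limit, no step size can be read from the measured compounds. The step that the limit leaves unreadable from compound 2 to compound 3 is expected to be none beyond the scatter, most likely ending again at a limit. Compound 3 is expected near 60000 nM, with a range of 20000 nM to 200000 nM.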

Compound 3, half-maximal effective concentration: > 52000 nM
Compound 3 was reported as a limit; the forecaster's own chance of this, stated with the estimate: 70%; the middle value does not contradict the limit.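

In this assay compound 3 gives > 52000 nM, a limit and not a number. With compound 2 also a limit, no step can be read between compound 2 and compound 3: the limit of > 52000 nM in this assay, at which 3 of the 3 values shown sit.

The compounds shown leave open which change, if any, would give a measurable value in this assay.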